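A few compounds are considered here, and "the series" means these few. Any claim that something is new, unique, unknown or untested is made for them only; others in the source may bear on it.

Compound 1 `CC(=O)c1ccc(NC(=O)CN(C(=O)c2ccccc2)S(=O)(=O)c2ccc(C)cc2)cc1` stands lowest of the three compounds measured in a functional assay for inhibition, read by spectrophotometry, with a stated time of 20 min, tested at 4 mg/mL; a lower number here means a weaker effect, a higher number a stronger effect of the compound at the concentration tested: compound 1 gives 18.5%. Compound 2 `CCC(C)C(C(=O)Nc1ccc(C(C)=O)cc1)N(C(=O)c1ccccc1)S(=O)(=O)c1ccc(C)cc1` gives 41.1% in this assay, and compound 3 `CC(=O)c1ccc(NC(=O)C(C(C)C)N(C(=O)c2ccccc2)S(=O)(=O)c2ccc(C)cc2)cc1` gives 36.6%. Both measured steps that start from compound 1 alter the saturated chain carbon bound to an amide-type nitrogen and a carbonyl carbon, and both raise the read-out by a modest amount beyond the scatter: a number 22.6 percentage points higher from compound 1 to compound 2 (beyond the scatter) and a number 18.1 percentage points higher from compound 1 to compound 3 (beyond the scatter). Between the two substituted compounds, a number 4.5 percentage points lower from compound 2 to compound 3 (within the scatter).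

Compound 4 `CC(=O)c1ccc(NC(=O)CN(C(=O)c2ccccc2)S(=O)(=O)c2ccccc2)cc1` differs from compound 1 at a different place altogether, on the ring carried by the sulfonyl group: hydrogen in place of methyl on an aromatic carbon Cut one bond further out, the (4-methylphenyl)sulfonyl group of compound 1 becomes a phenylsulfonyl group in compound 4.

None of the three measured steps touches this ring, so none of them bears on the change, and the data give no direction for it. The expected step from compound 1 is therefore one within the scatter, a number 0.5 percentage points lower from compound 1 to compound 4 (within the scatter). On that basis compound 4 is estimated to give about 18% in this assay, with a range from 6% to 32%.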

Compound 4, a percentage reported as inhibition, at one concentration (the size of the read-out at that concentration, not a potency): 40.9%
Compound 4: middle estimate off by 22.9 percentage points, on the low side, and the stated range ends below it.
By their numbers in this assay, from the lowest: compound 1; then compounds 3, 4 and 2 (each within the scatter of the next).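

In this assay, the ring carried by the sulfonyl group proves to be a second place where the read-out moves: the change from (4-methylphenyl)sulfonyl to phenylsulfonyl gives a number 22.4 percentage points higher from compound 1 to compound 4 (beyond the scatter). The earlier steps shown here all lay on the saturated chain, so they could not show that the removal of one methyl, a single carbon with no hydrogen-bond donors or acceptors and no net charge, is enough to produce a modest step beyond the scatter, and that the step runs upward, with hydrogen rather than methyl on this aromatic carbon going with the higher number in this pair. No measurement offered here accounts for the rise, so the reason for it remains unknown.

With only methyl and hydrogen shown on this aromatic carbon, it remains open how a methoxy group, a chlorine atom or an amine would read there. From the compounds shown here alone, it is also open whether the phenylsulfonyl group and a sec-butyl or isopropyl group on the chain carbon would add together in one compound or whether their gains would overlap.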